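Phenyl for Bromo on a Fatty Acid Receptor Agonist Series

The source may hold more compounds than are shown below. What is called first, only, known or untested is meant among the compounds shown, and "the series" means these compounds.

Measured compounds:
compound 1, `O=C(O)CCc1ccc(OCc2ccc(Br)cc2)cc1`, 98%
compound 2, `O=C(O)CCc1ccc(OCc2cccc(Br)c2)cc1`, 99%
compound 3, `O=C(O)CCc1ccc(NCc2ccc(-c3ccccc3)cc2)cc1`, 92%

In a functional assay on 1321-N1 cells for agonist activity at Free fatty acid receptor 1 (Homo sapiens), read by calcium flux (a higher number here means a larger maximal response, a lower number a smaller maximal response), compound 2 gives the highest of the three numbers, yet its gaps to compound 1 and to compound 3 both lie within the usual scatter, so the three compounds cannot be told apart on this read-out. Compound 4, `O=C(O)CCc1ccc(OCc2cccc(-c3ccccc3)c2)cc1`, has not been measured. It differs from compound 2 in one place: phenyl in place of bromo on an aromatic carbon. Compound 3 already carries a phenyl on the same outer ring and gives 92%, a number near that of compound 2. The step from compound 2 to compound 4 in this assay is therefore expected to be small, a number 4 percentage points lower from compound 2 to compound 4 (within the scatter), not beyond the scatter in either direction. Compound 4 is estimated at 95%, within a range of 80% to 105%.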

Compound 4, largest response reached (reported as efficacy), in percent of the reference or control that the assay uses: 105%
Beside the measured number, compound 4's estimate is 10 percentage points below it, and the stated range covers the measured number.
By their numbers in this assay, from the lowest: compounds 3, 1, 2 and 4 (each within the scatter of the next, the first and the last beyond it).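

In this assay, putting phenyl in place of bromo gives a number 6 percentage points higher from compound 2 to compound 4 (within the scatter), even though six heavy atoms and a whole aromatic ring replace a single bromine. This position, on an aromatic carbon meta to a large group, therefore holds a much larger group without a change in maximal response beyond the scatter. Nothing available here explains this result. On these data alone, whether an amine, a carboxylic acid or a longer chain at this position would also keep the response remains open.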